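The source may hold more compounds than are shown below. What is called first, only, known or untested is meant among the compounds shown, and "the series" means these compounds.

Measured so far in an assay on HEK293 cells for displacement of a labelled ligand from metabotropic glutamate receptor 5 (Rattus norvegicus); a lower number here means a stronger inhibitor, a higher number a weaker inhibitor:
compound 1 `O=C(Nc1cc(-c2ccccc2)nn1-c1ccccc1)c1cccc(C(F)(F)F)c1`, 1650 nM
compound 2 `N#Cc1cccc(C(=O)Nc2cc(-c3ccccc3)nn2-c2ccccc2Br)c1`, 230 nM
compound 3 `N#Cc1ccc(C(=O)N(C(=O)c2ccc(C#N)cc2)c2cc(-c3ccccc3)nn2-c2ccccc2)cc1`, 3050 nM

Among these values compound 1 stands second highest. Its nearest neighbour is compound 3, whose value lies within the scatter of that of compound 1, so no order can be read between them. Compound 2 gives a value beyond the scatter below that of compound 1.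

Compound 4 `O=C(Nc1cc(-c2ccccc2)nn1-c1ccccc1)C1CCCC1` differs from compound 1 in one place: cyclopentyl in place of 3-(trifluoromethyl)phenyl on a carbonyl carbon. Within the data shown here, no measured pair shows this change, so the step is not known from the data. Compound 4 is expected to be weaker than compound 1, with a step beyond the scatter a 3.0-fold higher number from compound 1 to compound 4 (0.48 log units; beyond the scatter). The value expected for compound 4 in this assay is 5000 nM, in the range 1500 nM to 16000 nM.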

Compound 4, inhibition constant: 11600 nM
The estimate for compound 4 lay 2.3-fold (0.37 log units) below the measured number, and the stated range covers the measured number.
By their numbers in this assay, from the lowest: compound 2; then compounds 1 and 3 (each within the scatter of the next); then compound 4.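

In this assay, cyclopentyl in place of 3-(trifluoromethyl)phenyl on the carbonyl carbon gives a weaker inhibitor, with a 7.0-fold higher number from compound 1 to compound 4 (0.85 log units; beyond the scatter). Among these compounds, this is the first single change that can be read at this position, and it shows that the group there matters for the value. Nothing available explains this loss.

The change swaps an aromatic ring for a non-aromatic one, alters ring size and removes the fluorine atoms all at once, so the compounds shown cannot separate these differences. Going by these compounds, how an unsubstituted phenyl or a cyclohexyl would fare at this position remains open.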